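The compounds below may be only part of what the source reports. "The series", "measured", "known", "first", "only" and "open" are said of these compounds alone.

In an ADME assay on Karpas-1106P cells (Homo sapiens) for cytotoxicity (on this read-out lower numbers stand for an effect already at smaller amounts and higher numbers for an effect only at larger amounts of compound), three compounds sharing one core have been tested, and none has yet given a true number. Compound 1 `Cc1ccc(S(=O)(=O)N[C@@H](CC(=O)NC(C)(C)C)C(=O)NCCNC(=O)c2cccc(O)c2)cc1` reads > 11100 nM, which is a limit of the assay and not a number. Compound 2 `Cc1ccc(S(=O)(=O)N[C@@H](CC(=O)NC(C)(C)C)C(=O)NCCNC(=O)c2cccc(C(C)C)c2)cc1` reads > 11100 nM, again a limit. Compound 3 `COc1cc(OC)cc(C(=O)NCCNC(=O)[C@H](CC(=O)NC(C)(C)C)NS(=O)(=O)c2ccc(C)cc2)c1` reads > 11100 nM, also a limit. Compound 3 therefore has no rank of its own, and the whole set shows (the limit of > 11100 nM in this assay, at which 3 of the 3 values shown sit).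

Compound 4 `Cc1ccc(S(=O)(=O)N[C@@H](CC(=O)NC(C)(C)C)C(=O)NCCNC(=O)NCc2ccccc2)cc1` has not been measured. It has benzylamino in place of 3,5-dimethoxyphenyl on a carbonyl carbon. Cut one bond further out, this is (3,5-dimethoxyphenyl)carbonyl to benzylcarbamoyl.

The measured steps offer no size to carry over. They are a step that the two limits leave unreadable from compound 1 to compound 2, then a step that the two limits leave unreadable from compound 1 to compound 3, and finally a step that the two limits leave unreadable from compound 2 to compound 3. The last two also change the group on the carbonyl carbon, so they bear most directly on this step, yet each still ends at the limit. In this assay the expected outcome is a step that the limit leaves unreadable from compound 3 to compound 4, an estimate with no clear direction and nothing expected beyond the scatter. For compound 4 the estimated value is 14000 nM, with an expected range of 6000 nM to 40000 nM, and the assay will probably report only a limit again.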

Compound 4, half-maximal effective concentration: > 11100 nM
Compound 4 ended at the assay's limit (the forecaster's own chance of this, stated with the estimate: 85%); the middle value lies beyond the limit too.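

Compound 4 gives > 11100 nM in this assay, which is a limit of the assay and not a number. Its steps from compound 1, compound 2 and compound 3 therefore cannot be read: the limit of > 11100 nM in this assay, at which 4 of the 4 values shown sit.

The four compounds shown leave open whether any of these groups on the carbonyl carbon changes the cytotoxicity read-out at all, and how the compounds would rank.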